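This account rests on a few compounds, and the source may have more. Where it says the series, first, only, none or still open, it means among the compounds named here.

Measured compounds:
compound 1, `COc1ccc(-c2ccc(C(=O)N[C@H](C)CCCc3cccnc3)cc2Br)cc1OC`: 180 nM
compound 2, `COc1ccc(-c2ccc(C(=O)NCCCCc3cccnc3)cc2OC)cc1OC`: 300 nM

In an assay (Canis lupus familiaris) for binding affinity to platelet-activating factor receptor (Homo sapiens), read by radioligand binding (a higher number here means a weaker inhibitor, a lower number a stronger inhibitor), compound 1 gives 180 nM, the lower of the two numbers, and compound 2 gives 300 nM. The gap between these two values lies within the usual scatter of repeated measurements, so the two compounds cannot be told apart in this assay.

Compound 3, `CCCc1cc(C(=O)N[C@H](C)CCCc2cccnc2)ccc1-c1ccc(OC)c(OC)c1`, has not yet been measured in this assay. It differs from compound 1 in a single place: propyl in place of bromo on an aromatic carbon. Going by the values given here, no measured pair shows what this exchange does to the numbers, so no direction can be taken from the data; a step in this assay of roughly the size of the scatter, in either direction, is what is expected. Compound 3 is therefore expected to give about 250 nM in this assay, with a range from 80 nM to 800 nM. The estimated step from compound 1 to compound 3 is a 1.4-fold higher number from compound 1 to compound 3 (0.14 log units; within the scatter).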

Compound 3, half-maximal inhibitory concentration: 50 nM
Estimate against measurement, compound 3: 5.0-fold (0.70 log units) above, and the stated range ends above it.
By their numbers in this assay, from the lowest: compound 3; then compounds 1 and 2 (each within the scatter of the next).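

In this assay, going by these compounds alone, propyl in place of bromo on this aromatic carbon gives a 3.6-fold lower number from compound 1 to compound 3 (0.56 log units; beyond the scatter) and so provides the first readable change. The position ortho to a 3,4-dimethoxyphenyl group therefore responds to what sits on it, and here 3 carbon atoms in place of 1 bromine bring a stronger inhibitor rather than a weaker one. The data offer no measured explanation for this step.

A single exchange leaves open whether a longer chain such as butyl, a ring such as cyclopropyl, or a group such as an amine or a carboxylic acid would lower the number further or raise it again on this carbon. It also leaves open whether the same exchange would have a similar effect with the side chain of compound 2.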